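A few compounds are considered here, and "the series" means these few. Any claim that something is new, unique, unknown or untested is made for them only; others in the source may bear on it.

Of the compounds shown here, two have been measured in an assay on CHO cells for antagonist activity at transient receptor potential cation channel subfamily V member 1 (Homo sapiens), read by FLIPR; on this read-out lower numbers stand for stronger inhibition and higher numbers for weaker inhibition. Within the data shown here, compound 1 `CC(C)CCSc1cc(C(F)(F)F)ccc1CNC(=O)C(C)c1ccc(NS(C)(=O)=O)c(F)c1` gives 1.4 nM, and compound 2 `CC(C(=O)NCc1ccc(C(F)(F)F)cc1-c1ccc(F)c(Cl)c1)c1ccc(NS(C)(=O)=O)c(F)c1` gives 0.6 nM, the lowest of the two numbers; the one measured step is a 2.3-fold lower number from compound 1 to compound 2 (0.37 log units; beyond the scatter). Compound 3 `COc1cc(OC)cc(-c2cc(C(F)(F)F)ccc2CNC(=O)C(C)c2ccc(NS(C)(=O)=O)c(F)c2)c1` differs from compound 2 in one place: 3,5-dimethoxyphenyl in place of 3-chloro-4-fluorophenyl on an aromatic carbon. Among the measured compounds shown here, no measured step exchanges one aryl group for another at this position. For the measured compounds named here, the single step so far replaced a chain with an aryl ring and bears on the present change only in showing that a substituted phenyl here gives the lower of the two numbers. Going by the values given here, with no direct precedent, the expected step in this assay for compound 3 is a 2.5-fold higher number from compound 2 to compound 3 (0.40 log units; beyond the scatter), a slight rise in number that may well stay within the scatter. Compound 3 is therefore estimated at 1.5 nM, with a range from 0.4 nM to 6 nM.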

Compound 3, inhibition constant: 5.8 nM
For compound 3 the middle estimate is 3.9-fold (0.59 log units) below the measured one, and the stated range covers the measured number.
By their numbers in this assay, from the lowest: compound 2; then compound 1; then compound 3.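

In this assay, this position responds strongly to the choice of aryl group: 3,5-dimethoxyphenyl in place of 3-chloro-4-fluorophenyl gives a 9.7-fold higher number from compound 2 to compound 3 (0.99 log units; beyond the scatter). An aryl group here therefore does not by itself give the lower number, as 3,5-dimethoxyphenyl in place of isopentylsulfanyl gives a 4.1-fold higher number from compound 1 to compound 3 (0.62 log units; beyond the scatter), opposite in direction to the step from the same chain to 3-chloro-4-fluorophenyl. Nothing at hand explains the rise in number.

The two aryl groups differ in several substituents at once, so the step cannot be divided between the arrival of the methoxy groups and the departure of the chlorine and fluorine. The compounds shown also leave open how a plain phenyl, a phenyl carrying a single methoxy group, or a phenyl carrying an amine would stand at this position.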